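The compounds below may be only part of what the source reports. "The series", "measured", "known", "first", "only" and "open" are said of these compounds alone.

Measured compounds:
- compound 1, `CSc1ccc(CNc2nc(SC)nc3ncccc23)cc1`: 190 nM
- compound 2, `COc1ccc(CNc2nc(SC)nc3ncccc23)cc1`: 34200 nM
- compound 3, `CSc1nc(NCCCCCO)c2cccnc2n1`: a limit, > 100000 nM

In an ADME assay on 184B5 cells (Homo sapiens) for cytotoxicity, read by MTT assay, with a stated time of 72 h (on this read-out lower numbers stand for stronger inhibition of growth and higher numbers for weaker inhibition of growth), compound 1 gives 190 nM and compound 2 gives 34200 nM. Going by the values given here, the one measured step, a 180-fold higher number from compound 1 to compound 2 (2.26 log units; beyond the scatter), shows that a small change at the end of the benzyl group moves this read-out a long way. Compound 3 stands apart: in this assay compound 3 reaches only a limit, > 100000 nM, and the evidence for this is the limit of > 100000 nM in this assay, at which 1 of the 3 values shown sits, so no number is known for it.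

Compound 4, `CSc1nc(NCc2ccccc2)c2cccnc2n1`, is reached by phenyl in place of 4-hydroxybutyl on a saturated chain carbon bound to a nitrogen on an aromatic ring. This gives compound 4 the same benzyl arrangement that compounds 1 and 2 carry, but with no group on the ring. Among the compounds with values here, no measured step matches this change, so the expectation rests on compounds 1 and 2 bracketing it. The step of an at least 5.0-fold lower number from compound 3 to compound 4 (0.69 log units; beyond the scatter) is therefore expected to run downward in this assay, and compound 4 is estimated at 20000 nM, in the range 2000 nM to 100000 nM.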

Compound 4, concentration for 50% growth inhibition: 49000 nM
The estimate for compound 4 lay 2.5-fold (0.39 log units) below the measured number, within the range that was stated.
By their numbers in this assay, from the lowest: compound 1; then compounds 2 and 4 (each within the scatter of the next). At a limit, above all of these: compound 3.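

Going by these compounds alone, compound 4, with hydrogen on that aromatic carbon, gives a reference point that the earlier compounds lacked. Against it, a 260-fold higher number from compound 1 to compound 4 (2.41 log units; beyond the scatter), which ties the low number of compound 1 to methylsulfanyl and not to the benzyl arrangement alone. Methoxy does not share this: a 1.4-fold higher number from compound 2 to compound 4 (0.16 log units; within the scatter), so in this assay it cannot be told apart from hydrogen. The swap of 4-hydroxybutyl for phenyl gives only a floor, an at least 2.0-fold lower number from compound 3 to compound 4 (0.30 log units; that floor lies within the scatter), and its true size cannot be read, since compound 3 is a limit: the limit of > 100000 nM in this assay, at which 1 of the 4 values shown sits.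

On these data alone, it remains open whether an ethylsulfanyl, a chlorine or an amine on that aromatic carbon would go with a number as low as that of compound 1. Also open, as far as these compounds go, is how a longer chain carrying an amine would compare with phenyl at the saturated chain carbon.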